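The source may hold more compounds than are shown below. What is called first, only, known or untested is meant among the compounds shown, and "the series" means these compounds.

In an ADME assay on L02 cells (Homo sapiens) for cytotoxicity, read by MTT assay, with a stated time of 24 h (a higher number here means a weaker inhibitor, a lower number a stronger inhibitor), compound 1 `CN1C/C(=C\c2cccc([N+](=O)[O-])c2)C(=O)/C(=C/c2ccccc2F)C1` gives 13500 nM and compound 2 `COc1cc(/C=C2\CN(C)C/C(=C\c3ccc(Br)cc3)C2=O)cc(OC)c1` gives 21300 nM on the same read-out. These two values lie within the usual scatter of each other, so the numbers do not set compound 2 apart from compound 1. Compound 3 `COc1cc(/C=C2\CN(C)C/C(=C\c3cccc([N+](=O)[O-])c3)C2=O)cc(OC)c1` differs from compound 2 in one place, with 3-nitrophenyl in place of 4-bromophenyl on a double-bonded chain carbon bound to a double-bonded ring carbon as the counted change: 3-nitrophenyl in place of 4-bromophenyl on a double-bonded chain carbon bound to a double-bonded ring carbon. Among the compounds with values here, no measured pair shows this change alone. Compound 1 already carries 3-nitrophenyl and gives 13500 nM in this assay without standing apart from compound 2, so no step beyond the scatter is expected. The estimate amounts to a 1.3-fold lower number from compound 2 to compound 3 (0.12 log units; within the scatter) and so stays within that scatter. In this assay compound 3 is estimated at 16000 nM with an expected range of 7000 nM to 36000 nM around that figure.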

Compound 3, half-maximal inhibitory concentration: 10800 nM
The estimate for compound 3 lay 1.5-fold (0.17 log units) above the measured number; the measured number falls inside the stated range.
By their numbers in this assay, from the lowest: compounds 3, 1 and 2 (each within the scatter of the next).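

In this assay, within the data shown here, 3-nitrophenyl in place of 4-bromophenyl on a double-bonded chain carbon bound to a double-bonded ring carbon gives a 2.0-fold lower number from compound 2 to compound 3 (0.29 log units; within the scatter), the first comparison here in which only one place differs. At this place, the read-out therefore does not separate the two groups, even though 3-nitrophenyl carries more heavy atoms and has hydrogen-bond acceptors that 4-bromophenyl lacks. Nothing available offers an explanation for this result.

The compounds shown leave open whether a different kind of group at this place, such as an amine or a carboxylic acid, would give a step beyond the scatter. They also leave open whether the same exchange would read alike with a different group elsewhere on the shared core.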